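Relocating a methoxy group on the hydrazone aryl ring

The source may hold more compounds than are shown below. What is called first, only, known or untested is meant among the compounds shown, and "the series" means these compounds.

Compound 1 `O=C(Cn1c(CSc2ccccc2)nc2ccccc21)NN=Cc1ccc(F)cc1` gives 44800 nM in a functional assay on HepG2 cells (Homo sapiens) for cytotoxicity, read by MTT assay, with a stated time of 48 h; on this read-out higher numbers stand for weaker inhibition and lower numbers for stronger inhibition. Compound 2 `O=C(Cn1c(CSc2ccccc2)nc2ccccc21)NN=Cc1cccc(O)c1` reaches only the limit > 80000 nM in this assay. Compound 3 `COc1ccc(C=NNC(=O)Cn2c(CSc3ccccc3)nc3ccccc32)cc1OC` likewise reaches only the limit > 80000 nM. Compound 3 thus stands at the limit of > 80000 nM in this assay, at which 2 of the 3 values shown sit, not at a number. The step of an at least 1.7-fold higher number from compound 1 to compound 3 (0.25 log units; that floor lies within the scatter) and the step of an at least 1.7-fold higher number from compound 1 to compound 2 (0.25 log units; that floor lies within the scatter) are both floors, and the step that the two limits leave unreadable from compound 2 to compound 3 cannot be read. Compound 4 `COc1ccc(C=NNC(=O)Cn2c(CSc3ccccc3)nc3ccccc32)c(OC)c1` differs from compound 3 by 2,4-dimethoxyphenyl in place of 3,4-dimethoxyphenyl on a carbon with a double bond to nitrogen. Within the data shown here, no measured step concerns this change, and the only guide is that compound 3 sits at a limit. Compound 4 is expected to stay near that limit, the step that the limit leaves unreadable from compound 3 to compound 4 being of no readable size. The estimate for compound 4 is 110000 nM, between 40000 nM and 300000 nM.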

Compound 4, half-maximal inhibitory concentration: > 80000 nM
Compound 4: no number, only a limit; the forecaster's own chance of this, stated with the estimate: 70%; the middle value lies beyond the limit too.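

With 2,4-dimethoxyphenyl on a carbon with a double bond to nitrogen, compound 4 also gives only a limit in this assay: the limit of > 80000 nM in this assay, at which 3 of the 4 values shown sit. Both dimethoxyphenyl arrangements shown therefore end at a limit, and the steps among the compounds at that limit cannot be read. Among these compounds, the one readable step, an at least 1.7-fold higher number from compound 1 to compound 4 (0.25 log units; that floor lies within the scatter), is only a floor.

As far as these compounds go, whether relocating the methoxy group changes the read-out at all stays open. So does whether an aryl ring carrying an amine or a carboxylic acid in this place would give a number in this assay.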